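This account rests on a few compounds, and the source may have more. Where it says the series, first, only, none or still open, it means among the compounds named here.

In a functional assay on DWD cells (Homo sapiens) for inhibition, read by sulforhodamine B assay (a higher number here means a weaker inhibitor of growth, a lower number a stronger inhibitor of growth), compound 1 `FC(F)(F)c1ccc(-c2ccc(-c3ccc(-c4nc5ccccc5[nH]4)cc3)cc2)cc1` gives 100000 nM. Compound 3 `Clc1cccc(-c2ccc(-c3ccc(-c4nc5ccccc5[nH]4)cc3)cc2)c1` stands level with it at 100000 nM, and these two share the highest of the three numbers, while compound 2 `Oc1ccc(-c2ccc(-c3ccc(-c4nc5ccccc5[nH]4)cc3)cc2)cc1` gives 46300 nM.

Compound 4 `Cc1ccc2[nH]c(-c3ccc(-c4ccc(-c5ccc(C(F)(F)F)cc5)cc4)cc3)nc2c1` keeps the substituted phenyl group of compound 1 and instead has methyl in place of hydrogen on an aromatic carbon, so that 1H-benzimidazol-2-yl becomes 5-methyl-1H-benzimidazol-2-yl: methyl in place of hydrogen on an aromatic carbon.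

For the measured compounds named here, none of the measured steps makes this change. All three exchange only the substituted phenyl group. The swap to the chloro compound gives no change at the digits printed from compound 1 to compound 3 (within the scatter), while the hydroxy compound gives a 2.2-fold lower number from compound 1 to compound 2 (0.33 log units; beyond the scatter) and the step back out of it gives a 2.2-fold higher number from compound 2 to compound 3 (0.33 log units; beyond the scatter). These steps bear on the new change only indirectly, and they show that the series has moved only modestly so far in this assay. A small move toward a lower number is therefore expected, and it may not clear the scatter. The expected step is a 1.3-fold lower number from compound 1 to compound 4 (0.10 log units; within the scatter). Compound 4 is estimated at 80000 nM, with an expected range from 30000 nM to 120000 nM.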

Compound 4, concentration for 50% growth inhibition: 38200 nM
The estimate for compound 4 lay 2.1-fold (0.32 log units) above the measured number, and the stated range covers the measured number.
By their numbers in this assay, from the lowest: compounds 4 and 2 (each within the scatter of the next); then compounds 1 and 3 (each within the scatter of the next).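

For the compounds shown here, the earlier compounds changed only the substituted phenyl group, so compound 4 gives the first reading at the other end of the molecule. In this assay, replacing 1H-benzimidazol-2-yl with 5-methyl-1H-benzimidazol-2-yl gives a 2.6-fold lower number from compound 1 to compound 4 (0.42 log units; beyond the scatter), showing that a single methyl on this ring can move the number beyond the scatter, though only modestly and, so far, only in this one pair. Nothing available here accounts for the step.

As far as these compounds go, it remains open whether the methyl has the same effect alongside the hydroxy group of compound 2 or the chloro group of compound 3, rather than only with the trifluoromethyl group of compound 1. Also open, from the compounds shown here alone, is how an ethyl chain, a methoxy group, an amine or a carboxylic acid would compare with methyl at this position.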